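This account rests on a few compounds, and the source may have more. Where it says the series, first, only, none or still open, it means among the compounds named here.

Measured so far:
compound 1 `CC(=O)N1CCC(C[C@@H](c2nc3ccc(C)cc3n2C)N2C(=O)CN(c3ccc(Oc4ccccc4)cc3)C2=O)CC1`: 1300 nM
compound 2 `CC(=O)N1CCC(C[C@@H](c2nc3cc(F)ccc3n2C)N2C(=O)CN(c3ccc(Oc4ccccc4)cc3)C2=O)CC1`: 8300 nM

Compound 2 stands highest of the two numbers in an assay on isolated protein for antagonist activity at Bile acid receptor (Homo sapiens), read by TR-FRET and LanthaScreen; on this read-out lower numbers stand for stronger inhibition and higher numbers for weaker inhibition. For the measured compounds named here, the single measured step is a 6.4-fold higher number from compound 1 to compound 2 (0.81 log units; beyond the scatter), and it bears directly on the next change, since it moves a substituent on the benzimidazole part of the shared core. Compound 3 `CC(=O)N1CCC(C[C@@H](c2nc3ccc(Cl)cc3n2C)N2C(=O)CN(c3ccc(Oc4ccccc4)cc3)C2=O)CC1` carries 6-chloro-1-methyl-1H-benzimidazol-2-yl in place of 5-fluoro-1-methyl-1H-benzimidazol-2-yl on a saturated chain carbon bound to an amide-type nitrogen in a ring and a saturated chain carbon. The step is expected to point in the opposite direction to that from compound 1 to compound 2, but the size of a return is uncertain. Compound 3 is estimated at 2500 nM, within 900 nM to 7000 nM. This estimate means a step of a 3.3-fold lower number from compound 2 to compound 3 (0.52 log units; beyond the scatter).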

Compound 3, half-maximal inhibitory concentration: 3500 nM
Estimate against measurement, compound 3: 1.4-fold (0.15 log units) below, within the range that was stated.
By their numbers in this assay, from the lowest: compound 1; then compound 3; then compound 2.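

In this assay, the 6-chloro-1-methyl-1H-benzimidazol-2-yl group gives part of the lost ground back, with a 2.4-fold lower number from compound 2 to compound 3 (0.38 log units; beyond the scatter), but chloro in place of methyl on an aromatic carbon still leaves a 2.7-fold higher number from compound 1 to compound 3 (0.43 log units; beyond the scatter). Among these three compounds, the methyl-bearing compound 1 keeps the lowest number. Nothing available explains either step.

The group names of compound 2 and compound 3 differ in both halogen and numbered position, so these two effects remain unseparated. As far as these compounds go, how a methoxy or nitrile on that aromatic carbon would compare with methyl remains open.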